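Shortening the hydroxycarbamoyl chain on the core of compound 1

The compounds below may be only part of what the source reports. "The series", "measured", "known", "first", "only" and "open" are said of these compounds alone.

Measured in a functional assay on HCT-116 cells (Homo sapiens) for inhibition, read by MTT assay, with a stated time of 72 h; on this read-out higher numbers stand for weaker inhibition and lower numbers for stronger inhibition:
- compound 1 `Nc1nc2cc(-c3nn(CCCC(=O)NO)c4ncnc(N)c34)ccc2o1`: 19600 nM
- compound 2 `Nc1ncnc2c1c(-c1cnc3[nH]ccc3c1)nn2CCCCCC(=O)NO`: 63700 nM
- compound 3 `Nc1ncnc2c1c(-c1cnc3[nH]ccc3c1)nn2CCC(=O)NO`: > 150000 nM (a limit, not a number)

Compound 1 holds the lowest of the two true numbers in this assay, and the number for compound 2 lies above it, beyond the scatter. The entry for compound 3 is only a limit: the limit of > 150000 nM in this assay, at which 1 of the 3 values shown sits.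

Compound 4 `Nc1nc2cc(-c3nn(CC(=O)NO)c4ncnc(N)c34)ccc2o1` keeps the core of compound 1 and changes the chain: hydroxycarbamoyl in place of 2-(hydroxycarbamoyl)ethyl on a saturated chain carbon bound to an aromatic nitrogen. The same difference reads 3-(hydroxycarbamoyl)propyl to (hydroxycarbamoyl)methyl.

Among the measured compounds shown here, one measured step bears on this, a chain shortening on a different core: an at least 2.3-fold higher number from compound 2 to compound 3 (0.37 log units; beyond the scatter). For the measured compounds named here, it ends at a limit, so its full size is unknown, and it is the only guide. A higher number is therefore expected in this assay, and compound 4 could also end up as a limit. The expected step is a 3.8-fold higher number from compound 1 to compound 4 (0.58 log units; beyond the scatter). Compound 4 is estimated at 75000 nM, with an expected range of 30000 nM to 150000 nM.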

Compound 4, half-maximal inhibitory concentration: 11400 nM
Beside the measured number, compound 4's estimate is 6.6-fold (0.82 log units) above it; measured number outside the range, below it.
By their numbers in this assay, from the lowest: compounds 4 and 1 (each within the scatter of the next); then compound 2. At a limit, above all of these: compound 3.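

In this assay, replacing 3-(hydroxycarbamoyl)propyl with (hydroxycarbamoyl)methyl on the core of compound 1 gives a step within the scatter: a 1.7-fold lower number from compound 1 to compound 4 (0.24 log units; within the scatter). On this core, the two chain lengths therefore cannot be told apart, a result not suggested by the only earlier chain shortening, a different change on a different core: an at least 2.3-fold higher number from compound 2 to compound 3 (0.37 log units; beyond the scatter). The entry for compound 3 remains a limit, not a number: the limit of > 150000 nM in this assay, at which 1 of the 4 values shown sits.

Going by these compounds, whether a longer chain on the core of compound 1, or a carboxylic acid in place of the hydroxycarbamoyl group, would stay within the scatter of compound 1 remains open. Among the compounds shown here, no pair here has the same chain on the two cores, so the role of the core in the different outcomes of the two shortenings also stays open.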